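Cytotoxicity of Three Pyridyl Compounds and a Fourth

A few compounds are considered here, and "the series" means these few. Any claim that something is new, unique, unknown or untested is made for them only; others in the source may bear on it.

Measured so far:
compound 1, `c1ccc(-c2nc3ccccn3c2Nc2ccc3c(c2)OCCO3)nc1`, 25600 nM in an ADME assay on THP-1 cells (Homo sapiens) for cytotoxicity; on this read-out higher numbers stand for lower toxicity in this test and lower numbers for higher toxicity in this test
compound 2, `c1ccc(-c2nc3ccccn3c2NCC2CC2)nc1`, 19400 nM in this assay
compound 3, `N#Cc1ccn2c(Nc3ccc(F)cc3)c(-c3ccccn3)nc2c1`, > 50000 nM in this assay

In this assay compound 1 gives 25600 nM and compound 2 gives 19400 nM. For compound 3 the read-out is only a limit, > 50000 nM; this is the limit of > 50000 nM in this assay, at which 1 of the 3 values shown sits, so its place among the numbers is not fixed. Compound 4, `Fc1ccc(Nc2c(-c3ccccn3)nc3cc(C(F)(F)F)ccn23)cc1`, differs from compound 3 by trifluoromethyl in place of cyano on an aromatic carbon. Among the measured compounds shown here, no step between two measured compounds is available for this change, and it is not expected to move the half-maximal cytotoxic concentration beyond the scatter in either direction. Compound 4 is therefore expected to give 45000 nM, between 15000 nM and 150000 nM, which is the expected step of an at least 1.1-fold lower number from compound 3 to compound 4 (0.04 log units; that floor lies within the scatter).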

Compound 4, half-maximal cytotoxic concentration: 23700 nM
The estimate for compound 4 lay 1.9-fold (0.28 log units) above the measured number, within the range that was stated.
By their numbers in this assay, from the lowest: compounds 2, 4 and 1 (each within the scatter of the next). At a limit, above all of these: compound 3.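

On an aromatic carbon opposite the ring nitrogen, the group placed there makes a measurable difference in this assay: trifluoromethyl in place of cyano gives an at least 2.1-fold lower number from compound 3 to compound 4 (0.32 log units; beyond the scatter). This is the first single-place change among the compounds shown, and it lies beyond the scatter. Its full size cannot be given because compound 3 stands at a limit and not at a number: the limit of > 50000 nM in this assay, at which 1 of the 4 values shown sits.

The compounds shown leave open how an amine, a carboxylic acid or a methoxy group would read at this position. They also leave open whether the same change gives a similar step when the rest of the molecule differs.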